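Shifting a Fluorine Across Three Weak Inhibitors

A few compounds are considered here, and "the series" means these few. Any claim that something is new, unique, unknown or untested is made for them only; others in the source may bear on it.

Of the compounds shown here, three have been measured in a functional assay on DU-145 cells (Homo sapiens) for inhibition; a lower number here means a stronger inhibitor, a higher number a weaker inhibitor.
Compound 1, `Oc1ccccc1-c1cc(-c2ccc(F)cc2)cc(-c2ccccc2O)n1`, gives > 50000 nM, which is a limit of the assay.
Compound 2, `Oc1cccc(-c2cc(-c3ccccc3F)cc(-c3ccccc3O)n2)c1`, gives 35600 nM.
Compound 3, `Oc1cccc(-c2cc(-c3cccc(F)c3)cc(-c3ccccc3O)n2)c1`, gives > 50000 nM, again a limit.

Compound 3 thus stands at the assay limit rather than at a number. For the measured compounds named here, the single measured step, an at least 1.4-fold higher number from compound 2 to compound 3 (0.14 log units; that floor lies within the scatter), also moved the fluorine on that ring and stayed within the scatter. The change to compound 4, `Oc1cccc(-c2cc(-c3ccc(F)cc3)cc(-c3ccccc3O)n2)c1`, is 4-fluorophenyl in place of 3-fluorophenyl on an aromatic carbon. Compound 1 carries the same 4-fluorophenyl group and sits at the limit of > 50000 nM in this assay, at which 2 of the 3 values shown sit. No step beyond the scatter is therefore expected in this assay. Compound 4 is expected to give 50000 nM, within a range from 25000 nM to 100000 nM. The expected step is a number no higher from compound 3 to compound 4 (the limit leaves the size open), most likely reported only as a limit.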

Compound 4, half-maximal inhibitory concentration: > 50000 nM
Compound 4 gave a limit, no number; the forecaster's own chance of this, stated with the estimate: 80%; the middle value sits exactly at the limit.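

Compound 4 completes the set of three fluorophenyl placements on the core of compound 2, and it adds a second readable step at this position, an at least 1.4-fold higher number from compound 2 to compound 4 (0.14 log units; that floor lies within the scatter). The 4-fluorophenyl group, like the 3-fluorophenyl group, is therefore not shown to differ from the 2-fluorophenyl group, while the steps from compound 3 and from compound 1 to compound 4 cannot be read. The limit now holds most of the series: the limit of > 50000 nM in this assay, at which 3 of the 4 values shown sit.

From the compounds shown here alone, how far the two limit compounds truly lie from compound 2 stays open. So does whether an amine or a carboxylic acid in place of the fluorophenyl group would give a measurable number in this assay.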